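This account rests on a few compounds, and the source may have more. Where it says the series, first, only, none or still open, it means among the compounds named here.

Compound 1 `CCCc1ccc(COC(=O)N[C@H]2CNC2=O)cc1` stands second highest of the three numbers in an assay on HEK293 cells for inhibition of N-acylethanolamine-hydrolyzing acid amidase (Homo sapiens), read by fluorescence, with stated times of 10 min and 50 min (a higher number here means a weaker inhibitor, a lower number a stronger inhibitor), where compound 1 gives 52 nM. Its nearest neighbour is compound 2 `CCCCc1ccc(COC(=O)N[C@H]2CNC2=O)cc1`, which in this assay gives 23 nM; the step of a 2.3-fold lower number from compound 1 to compound 2 (0.35 log units; beyond the scatter). Compound 3 `O=C(N[C@H]1CNC1=O)OCc1ccc2c(c1)CCC2` gives 130 nM in this assay, the highest of the three. Compound 4 `O=C(N[C@H]1CNC1=O)OCc1ccc(-c2cccnc2)cc1` differs from compound 1 by pyridin-3-yl in place of propyl on an aromatic carbon. For the measured compounds named here, only the step from compound 1 to compound 2 bears on this change, and loosely, since it lengthens the chain by a methyl rather than exchanging the chain for a ring. Nothing measured here shows what a six-membered aromatic ring in that place does. The expected step is therefore modest and uncertain in direction: a 1.3-fold lower number from compound 1 to compound 4 (0.11 log units; within the scatter). Compound 4 is estimated at 40 nM, between 12 nM and 130 nM.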

Compound 4, half-maximal inhibitory concentration: 8110 nM
Compound 4: middle estimate off by 200-fold (2.31 log units), on the low side; measured number above the stated range.
By their numbers in this assay, from the lowest: compound 2; then compound 1; then compound 3; then compound 4.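

Replacing a saturated chain with an aromatic ring at this carbon, para to a large group, is not a small change: pyridin-3-yl in place of propyl gives a 160-fold higher number from compound 1 to compound 4 (2.19 log units; beyond the scatter) in this assay, and pyridin-3-yl in place of butyl gives a 350-fold higher number from compound 2 to compound 4 (2.55 log units; beyond the scatter) in the same assay. The earlier compounds shown here showed only a modest shift between two chains, so this position proves far more sensitive than they suggested. Nothing available explains this loss.

From the compounds shown here alone, it remains open whether phenyl, which lacks the ring nitrogen, would behave like pyridin-3-yl or like the chains. Going by these compounds, whether a longer chain such as hexyl would lower the number further is also open.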